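The source may hold more compounds than are shown below. What is called first, only, known or untested is meant among the compounds shown, and "the series" means these compounds.

Compound 1 `COc1ncc(-c2ccccc2)cc1[C@@H](c1ccccc1)[C@@](O)(CCN(C)C)c1cccc2ccccc12` is reported only as a limit of the assay: in a toxicity assay on Vero cells (Chlorocebus sabaeus) for cytotoxicity (a higher number here means that more compound is tolerated, a lower number that less compound is tolerated), compound 1 gives > 50 ug/mL.
Compound 2 `COc1nc(-c2cnsc2)ccc1[C@@H](c1ccccc1)[C@@](O)(CCN(C)C)c1cccc2ccccc12`: in this assay compound 2 gives 26.3 ug/mL.
Compound 3 `COc1ncc(-c2ccccc2)cc1[C@@H](c1ccccc1)[C@@](O)(CCN(C)C)c1cccc(F)c1F` is likewise reported only as a limit: in this assay compound 3 gives > 50 ug/mL.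

Among these three results, compound 2 stands as the only one given as a true number; the other two sit at the limit of > 50 ug/mL in this assay, at which 2 of the 3 values shown sit, so they cannot be ordered against it. Going by the values given here, the single measured step, a step that the two limits leave unreadable from compound 1 to compound 3, alters a different part of the shared core and its size cannot be read, so no measured step bears directly on the change considered here.

Compound 4 `COc1nc(C2CCCCC2)ccc1[C@@H](c1ccccc1)[C@@](O)(CCN(C)C)c1cccc2ccccc12` differs from compound 2 by cyclohexyl in place of 1,2-thiazol-4-yl on an aromatic carbon. Without any comparable measured step, no shift beyond the usual scatter is expected, and the step from compound 2 to compound 4 is estimated at a 1.1-fold higher number from compound 2 to compound 4 (0.06 log units; within the scatter) in this assay. Compound 4 is accordingly expected to give 30 ug/mL, within a range from 12 ug/mL to 60 ug/mL.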

Compound 4, half-maximal cytotoxic concentration: 32.3 ug/mL
For compound 4 the middle estimate is 1.1-fold (0.03 log units) below the measured one, and the stated range covers the measured number.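

Unlike the earlier step, which two limits left unreadable, this one joins two true numbers, and it is the first reading at this position, on the aromatic carbon next to the ring nitrogen: in this assay the change gives a 1.2-fold higher number from compound 2 to compound 4 (0.09 log units; within the scatter). A cyclohexyl ring of carbon only, with no hydrogen-bond acceptors, can thus replace the aromatic 1,2-thiazol-4-yl ring, with its nitrogen and sulfur, and the two values remain within the usual scatter of each other. Nothing measured here gives a reason for this outcome.

From the compounds shown here alone, what a primary amine or a carboxylic acid at this position would do to the number remains open. Also open, going by these compounds, is whether the same swap would read alike on a core carrying 2,3-difluorophenyl in place of naphthalen-1-yl.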